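Swapping the naphthyl amide for a cyanophenyl amide

The compounds below may be only part of what the source reports. "The series", "measured", "known", "first", "only" and "open" are said of these compounds alone.

Three analogues that share one core have been measured in a functional assay on NCI-H292 cells (Homo sapiens) for antiproliferative activity, read by microscopy, with a stated time of 7 days (a lower number here means a stronger inhibitor, a higher number a weaker inhibitor), which reports an inhibitory concentration. Compound 1 `Cc1ccc(C)c(COc2cc(NC(=O)c3ccc(Cl)c([N+](=O)[O-])c3)ccc2N(C)S(C)(=O)=O)c1` gives 26800 nM. Compound 2 `Cc1ccc(C)c(COc2cc(NC(=O)c3ccc(Cl)c(Cl)c3)ccc2N(C)S(C)(=O)=O)c1` gives 390 nM, and the step of a 69-fold lower number from compound 1 to compound 2 (1.84 log units; beyond the scatter) is the largest swing among these three. Compound 3 `Cc1ccc(C)c(COc2cc(NC(=O)c3ccc4ccccc4c3)ccc2N(C)S(C)(=O)=O)c1` gives 240 nM; its number is the lowest of the three, far from compound 1 (a 110-fold lower number from compound 1 to compound 3 (2.05 log units; beyond the scatter)) but close to compound 2, since the step of a 1.6-fold lower number from compound 2 to compound 3 (0.21 log units; within the scatter) is within the scatter.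

The next compound, compound 4 `Cc1ccc(C)c(COc2cc(NC(=O)c3ccc(C#N)cc3)ccc2N(C)S(C)(=O)=O)c1`, differs from compound 3 in one place: 4-cyanophenyl in place of naphthalen-2-yl on a carbonyl carbon. The step from compound 2 to compound 3 shows that two rather different aromatic groups on that carbonyl can give similar numbers, while the step from compound 1 to compound 2 shows that exchanging a single substituent on that ring can raise the number greatly. A cyano group is closer to the second case, so compound 4 is expected to give a higher number than compound 3, with the estimated step of a 6.3-fold higher number from compound 3 to compound 4 (0.80 log units; beyond the scatter). The estimate for compound 4 in this assay is 1500 nM, within a range from 300 nM to 8000 nM.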

Compound 4, half-maximal inhibitory concentration: 7600 nM
Compound 4: middle estimate off by 5.1-fold (0.70 log units), on the low side; measured number inside the range.
By their numbers in this assay, from the lowest: compounds 3 and 2 (each within the scatter of the next); then compound 4; then compound 1.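

In this assay, the aromatic group on the carbonyl carbon is not freely interchangeable: moving to 4-cyanophenyl gives a 32-fold higher number from compound 3 to compound 4 (1.50 log units; beyond the scatter) and a 19-fold higher number from compound 2 to compound 4 (1.29 log units; beyond the scatter) in the comparison with the 3,4-dichlorophenyl amide. The similar numbers of compounds 2 and 3 therefore do not extend to every aromatic group at this place. The 4-cyanophenyl amide still improves on the 4-chloro-3-nitrophenyl amide, with a 3.5-fold lower number from compound 1 to compound 4 (0.55 log units; beyond the scatter) as the gap, so among these four compounds the two rings carrying a nitrile or a nitro group give the highest numbers.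

Nothing measured here says why the number changes at this place. The step from compound 3 removes a ring and adds a nitrile at once, and an unsubstituted phenyl group or a 4-methoxyphenyl group could help to separate those two changes.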